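Ether side-chain variation on the shared core

The compounds below may be only part of what the source reports. "The series", "measured", "known", "first", "only" and "open" are said of these compounds alone.

Compound 1 `O=c1c(-c2ccc(O)cc2)coc2cc(OCC(O)CO)ccc12` and compound 2 `O=c1c(-c2ccc(O)cc2)coc2cc(OCCC3OCCCO3)ccc12` differ only in the chain on the aromatic ether oxygen of the shared core. Among the compounds with values here, in a functional assay on mitochondria (Cricetulus griseus) for inhibition of Monoamine oxidase (Homo sapiens), tested at 0.9 uM (a higher number here means a stronger effect of the compound at the concentration tested, a lower number a weaker effect), compound 1 gives 63.8% and compound 2 gives 57.6%; the step of a number 6.2 percentage points lower from compound 1 to compound 2 (within the scatter) leaves compound 2 inside the scatter of compound 1, the only other number measured. Compound 3 `C=CCOc1ccc2c(=O)c(-c3ccc(O)cc3)coc2c1` carries a group of 2 heavy atoms (2 carbon; no ring) in place of a group of 7 heavy atoms (5 carbon, 2 oxygen; one six-membered non-aromatic ring with 2 hetero atoms), on a saturated chain carbon bound to an oxygen on an aromatic ring. Within the data shown here, the single measured step at this place, a number 6.2 percentage points lower from compound 1 to compound 2 (within the scatter), stayed within the scatter, so no step beyond the scatter is expected in this assay. Compound 3 is therefore estimated at 57% (range 40% to 74%). The expected change is a number 0.6 percentage points lower from compound 2 to compound 3 (within the scatter).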

Compound 3, a percentage reported as inhibition, at one concentration (the size of the read-out at that concentration, not a potency): 68.8%
Compound 3: middle estimate off by 11.8 percentage points, on the low side, within the range that was stated.
By their numbers in this assay, from the lowest: compounds 2, 1 and 3 (each within the scatter of the next, the first and the last beyond it).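

In this assay this position now shows its first step beyond the scatter: a number 11.2 percentage points higher from compound 2 to compound 3 (beyond the scatter) when vinyl replaces the group with the six-membered non-aromatic ring. By contrast, a number 5 percentage points higher from compound 1 to compound 3 (within the scatter) with vinyl in place of 1,2-dihydroxyethyl, so these two side chains are not separated here. No measured evidence bears on the reason for this result.

Still open, as far as these compounds go, is how an amine or a carboxylic acid on this chain, or a longer saturated chain, would read in this assay at this position.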